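The source may hold more compounds than are shown below. What is called first, only, known or untested is meant among the compounds shown, and "the series" means these compounds.

Values in an ADME assay on L6 cells (Rattus norvegicus) for cytotoxicity, read by resazurin assay, with a stated time of 72 h; a lower number here means a stronger inhibitor, a higher number a weaker inhibitor:
- compound 1 `CN1CCN(CCC(=O)NC2CC3(N4CCCCC4)CC(c4ccccc4)C2C(c2ccccc2)C3)CC1` gives 61100 nM
- compound 2 `O=C(CN1CCCCC1)OC1CC2(N3CCCCC3)CC(c3ccccc3)C1C(c1ccccc1)C2` gives 60400 nM

Compound 2 stands level with compound 1 on these numbers, the gap lying within the scatter. Compound 3 `CN1CCN(CC(=O)NC2CC3(N4CCCCC4)CC(c4ccccc4)C2C(c2ccccc2)C3)CC1` follows from compound 2 through (((4-methylpiperazin-1-yl)methyl)carbonyl)amino in place of (((piperidin-1-yl)methyl)carbonyl)oxy on a saturated ring carbon on a saturated ring carbon. For the measured compounds named here, the one measured step that bears on this is a 1.0-fold lower number from compound 1 to compound 2 (0.01 log units; within the scatter) and it lies within the scatter, although it exchanges the same carbonyl-amino and carbonyl-oxy links and the same piperidin-1-yl and 4-methylpiperazin-1-yl rings. A step of a 1.0-fold lower number from compound 2 to compound 3 (0.00 log units; within the scatter) is expected in this assay and nothing beyond the scatter is foreseen. For compound 3 the estimate is 60000 nM with an expected range of 30000 nM to 120000 nM in this read-out.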

Compound 3, half-maximal inhibitory concentration: 57500 nM
Compound 3: middle estimate off by 1.0-fold (0.02 log units), on the high side; low and high end bracket the measured number.
By their numbers in this assay, from the lowest: compounds 3, 2 and 1 (each within the scatter of the next).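

Swapping (((piperidin-1-yl)methyl)carbonyl)oxy for (((4-methylpiperazin-1-yl)methyl)carbonyl)amino on this saturated ring carbon stays within the scatter in this assay (a 1.1-fold lower number from compound 2 to compound 3 (0.02 log units; within the scatter)). Placing 4-methylpiperazin-1-yl in place of (4-methylpiperazin-1-yl)methyl on the saturated chain carbon bound to the carbonyl carbon also stays within the scatter (a 1.1-fold lower number from compound 1 to compound 3 (0.03 log units; within the scatter)). No measured evidence accounts for these results.

As far as these compounds go, whether a primary amine or a carboxylic acid at this position would shift the read-out beyond the scatter remains open.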